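Cyclopentyl amide in the valine piperidine series

A few compounds are considered here, and "the series" means these few. Any claim that something is new, unique, unknown or untested is made for them only; others in the source may bear on it.

Within the data shown here, compound 2 `CC(C)[C@@H](NC(=O)CC1CC1)C(=O)N1CCC(c2ccc(Cl)cc2)CC1` has the lowest of the two numbers measured so far in an assay on THP-1 cells for displacement of a labelled ligand from C-C chemokine receptor type 1 (Homo sapiens); a lower number here means a stronger inhibitor, a higher number a weaker inhibitor: compound 2 gives 46 nM. Among the measured compounds shown here, compound 1 `CC(C)C(NC(=O)c1ccccc1)C(=O)N1CCN(c2ccc(Cl)cc2)CC1` differs from compound 2 in more than one place, so no single step connects the pair; in this assay compound 1 gives 525 nM, a gap beyond the scatter, and nothing further is read from it. Compound 3 `CC(C)[C@@H](NC(=O)C1CCCC1)C(=O)N1CCC(c2ccc(Cl)cc2)CC1` is the next compound for this assay. It keeps the whole of compound 2 apart from the acyl group: cyclopentyl in place of cyclopropylmethyl on a carbonyl carbon. One small saturated carbon-only ring is exchanged for another of similar kind, so in this assay no step beyond the scatter is expected in either direction. For compound 3 the estimate in this assay is 50 nM, with a range of 18 nM to 140 nM. The estimated step of a 1.1-fold higher number from compound 2 to compound 3 (0.04 log units; within the scatter) is therefore expected to sit within the usual scatter.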

Compound 3, half-maximal inhibitory concentration: 70 nM
Beside the measured number, compound 3's estimate is 1.4-fold (0.15 log units) below it; the measured number falls inside the stated range.
By their numbers in this assay, from the lowest: compounds 2 and 3 (each within the scatter of the next); then compound 1.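

In this assay, among these compounds, replacing cyclopropylmethyl with cyclopentyl on a carbonyl carbon gives a 1.5-fold higher number from compound 2 to compound 3 (0.18 log units; within the scatter), the only single-place step available so far. At this place, a three-membered carbon ring on a cyclopropylmethyl group and a five-membered carbon ring in a cyclopentyl group are therefore not told apart, although the heavy-atom count goes from 4 to 5 and neither group carries a hydrogen-bond donor or acceptor. No measurement that would explain this result is at hand.

Both groups are saturated carbon-only rings, so the step does not show whether an amine, a carboxylic acid or a longer open chain at this place would give a step beyond the scatter. Among the compounds shown here, the link from compound 1 to this pair remains unreadable, as no single step connects them.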